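Removing a methoxy group from a pyrazole-bridged chalcone

A few compounds are considered here, and "the series" means these few. Any claim that something is new, unique, unknown or untested is made for them only; others in the source may bear on it.

Compound 1: `COc1ccc(C(=O)/C=C/c2cc(-c3cc(OC)c(OC)c(OC)c3)n[nH]2)cc1OC`, 5520 nM
Compound 2: `COc1cc(C(=O)/C=C/c2cc(-c3cc(OC)c(OC)c(OC)c3)n[nH]2)cc(OC)c1OC`, 5820 nM

In a functional assay on MDA-MB-435 cells (Homo sapiens) for inhibition, read by sulforhodamine B assay, with a stated time of 48 h (a lower number here means that less compound is tolerated, a higher number that more compound is tolerated), compound 2 gives 5820 nM, and compound 1 gives 5520 nM; the two lie within the scatter of each other, so neither can be called more tolerated than the other. Compound 3, `COc1ccc(-c2cc(/C=C/C(=O)c3cc(OC)c(OC)c(OC)c3)[nH]n2)cc1OC`, differs from compound 2 by hydrogen in place of methoxy on an aromatic carbon. Going by the values given here, the only measured step that bears on such a change is the one from compound 1 to compound 2, which is the reverse kind of change, a methoxy group entering on an aromatic carbon, and it gave a 1.1-fold higher number from compound 1 to compound 2 (0.02 log units; within the scatter). With that step inside the scatter, no shift beyond the scatter is expected in this assay from compound 2 to compound 3 either; the expected step is a 1.0-fold lower number from compound 2 to compound 3 (0.00 log units; within the scatter). Compound 3 is therefore estimated at 5800 nM, with a range from 2500 nM to 13000 nM.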

Compound 3, concentration lethal to 50% of the cells: 9200 nM
Compound 3: the middle estimate sits 1.6-fold (0.20 log units) below what was measured, within the range that was stated.
By their numbers in this assay, from the lowest: compounds 1, 2 and 3 (each within the scatter of the next).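

In this assay the swap of methoxy for hydrogen gives a 1.6-fold higher number from compound 2 to compound 3 (0.20 log units; within the scatter) and so leaves the number within the usual scatter. A methoxy group on this aromatic carbon, ortho to a methoxy group and meta to a large group, can therefore be lost without a clear shift in this cell-killing read-out. The earlier step concerned a methoxy group on the aromatic ring that carries the carbonyl, whereas this one concerns the other aromatic ring, so a single methoxy change on either ring has now stayed within the scatter.

From the compounds shown here alone, whether a hydroxyl group, an amine or a fluorine atom on this same carbon would also stay within the scatter remains open. Nothing available explains the size of this step.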